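This account rests on a few compounds, and the source may have more. Where it says the series, first, only, none or still open, it means among the compounds named here.

For the measured compounds named here, in a functional assay on BXPC-3 cells (Homo sapiens) for cytotoxicity, read by MTT assay (on this read-out higher numbers stand for weaker inhibition and lower numbers for stronger inhibition), three compounds built on a shared core have numbers so far: compound 1 `Oc1ccc(CN(Cc2ccccc2)Cc2ccc(O)c3ncccc23)c2cccnc12` gives 7440 nM, compound 2 `Oc1ccc(CN(Cc2cccc(C(F)(F)F)c2)Cc2ccc(O)c3ncccc23)c2cccnc12` gives 167 nM, and compound 3 `Oc1ccc(CN(Cc2cc(C(F)(F)F)cc(C(F)(F)F)c2)Cc2ccc(O)c3ncccc23)c2cccnc12` gives 79 nM. Compound 2 therefore has the second highest of the three numbers, and it lies far closer to compound 3 than to compound 1.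

Compound 4 `Oc1ccc(CN(Cc2cccs2)Cc2ccc(O)c3ncccc23)c2cccnc12` has not yet been measured. It differs from compound 2 in one place: thiophen-2-yl in place of 3-(trifluoromethyl)phenyl on a saturated chain carbon bound to an amine nitrogen. Thiophen-2-yl thus stands in place of 3-(trifluoromethyl)phenyl on a saturated chain carbon bound to an amine nitrogen.

Going by the values given here, no measured step makes this exact exchange, but two bear on it. The first trifluoromethyl in place of hydrogen on an aromatic carbon goes with a 45-fold lower number from compound 1 to compound 2 (1.65 log units; beyond the scatter), a large step, and the second goes with a 2.1-fold lower number from compound 2 to compound 3 (0.33 log units; beyond the scatter), a modest one. Among the compounds with values here, compound 4 carries no trifluoromethyl, so it is expected to fall nearer compound 1, at 7440 nM, than compound 2, although no measured compound shows how thiophen-2-yl compares with phenyl. A large rise in this assay is therefore expected, with an estimated 18-fold higher number from compound 2 to compound 4 (1.25 log units; beyond the scatter). The estimate for compound 4 is 3000 nM, with an expected range from 700 nM to 10000 nM.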

Compound 4, half-maximal inhibitory concentration: 89 nM
Compound 4: middle estimate off by 34-fold (1.53 log units), on the high side; measured number outside the range, below it.
By their numbers in this assay, from the lowest: compounds 3, 4 and 2 (each within the scatter of the next, the first and the last beyond it); then compound 1.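

In this assay, a large drop on this saturated chain carbon bound to an amine nitrogen proves not to depend on trifluoromethyl: thiophen-2-yl in place of phenyl goes with an 84-fold lower number from compound 1 to compound 4 (1.92 log units; beyond the scatter), a step as clearly beyond the scatter as the one seen earlier with trifluoromethyl, a 45-fold lower number from compound 1 to compound 2 (1.65 log units; beyond the scatter). Thiophen-2-yl in place of 3-(trifluoromethyl)phenyl gives a 1.9-fold lower number from compound 2 to compound 4 (0.27 log units; within the scatter), so these two groups cannot be told apart here, although thiophen-2-yl has fewer heavy atoms and carries no fluorine, and compound 1, with its plain phenyl, now stands alone among the compounds compared with it here. Nothing available here explains why thiophen-2-yl and 3-(trifluoromethyl)phenyl give such similar results in this assay.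

The compounds shown leave open whether this result belongs to thiophen-2-yl specifically or would extend to other rings in this place, such as thiophen-3-yl, furan-2-yl or pyridin-2-yl. They also leave open whether trifluoromethyl or chlorine on the thiophen-2-yl ring would lower the number further, as the second trifluoromethyl did modestly in a 2.1-fold lower number from compound 2 to compound 3 (0.33 log units; beyond the scatter).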